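The compounds below may be only part of what the source reports. "The series", "measured", "known", "first", "only" and "open" are said of these compounds alone.

Working notes on the series.

Compound 1 `CCOc1ncc(-c2nc(C(F)(F)F)sc2N2CCN(C(=O)Cn3nccc3C)[C@H](C)C2)cn1` and compound 2 `CCOc1ncc(-c2nc(C(F)(F)F)sc2N2CCN(C(=O)Cn3nc(C)cc3C)[C@H](C)C2)cn1` share one core and differ only at the five-membered ring on the chain carbon bound to the carbonyl. In an assay on blood for inhibition of C-X-C chemokine receptor type 3 (Homo sapiens), with a stated time of 30 min (on this read-out higher numbers stand for weaker inhibition and lower numbers for stronger inhibition), compound 1 gives 289 nM, and compound 2 gives 60 nM. The step of a 4.8-fold lower number from compound 1 to compound 2 (0.68 log units; beyond the scatter) is the only measured step so far, and on it compound 2 stands with the lowest of the two numbers shown.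

Compound 3 `CCOc1ncc(-c2nc(C(F)(F)F)sc2N2CCN(C(=O)Cn3nc(C)nc3C)[C@H](C)C2)cn1` differs from compound 2 by 3,5-dimethyl-1H-1,2,4-triazol-1-yl in place of 3,5-dimethyl-1H-pyrazol-1-yl on a saturated chain carbon bound to a carbonyl carbon. Going by the values given here, no measured step in this assay bears on an exchange of this kind: the one step known, from compound 1 to compound 2, concerns a methyl added to an aromatic carbon, not a ring nitrogen, so it gives no direction for the present change. For compound 3 the step of a 1.8-fold higher number from compound 2 to compound 3 (0.26 log units; within the scatter) is therefore expected to stay small, with no clear direction. In this assay compound 3 is estimated at 110 nM, with a range from 30 nM to 400 nM.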

Compound 3, half-maximal inhibitory concentration in the C-X-C chemokine receptor type 3 assay: 364 nM
Beside the measured number, compound 3's estimate is 3.3-fold (0.52 log units) below it, within the range that was stated.
By their numbers in the C-X-C chemokine receptor type 3 assay, from the lowest: compound 2; then compounds 1 and 3 (each within the scatter of the next).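

At this position, on a saturated chain carbon bound to a carbonyl carbon, the ring hetero atoms matter as well as the methyl groups: in the C-X-C chemokine receptor type 3 assay 3,5-dimethyl-1H-1,2,4-triazol-1-yl in place of 3,5-dimethyl-1H-pyrazol-1-yl gives a 6.1-fold higher number from compound 2 to compound 3 (0.78 log units; beyond the scatter). In the C-X-C chemokine receptor type 3 assay the second new step reads a 1.3-fold higher number from compound 1 to compound 3 (0.10 log units; within the scatter), so the gain carried by compound 2 does not persist once the ring is exchanged, even with both methyl groups in place. In a physicochemical assay for lipophilicity, at pH 7.4 (on this read-out higher numbers stand for higher lipophilicity and lower numbers for lower lipophilicity), compound 2 gives 3.7 and compound 3 gives 2.8. The same exchange also shifts the distribution coefficient: the measured distribution coefficient of compound 2, 3.7, and of compound 3, 2.8, a number 0.90 log units lower (beyond the scatter).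

Going by these compounds alone, only this pair carries both read-outs, so whether the loss of inhibition follows the distribution coefficient or the change of ring itself stays open. Also open, going by these compounds, is how an imidazole or a carboxylic acid on the same chain carbon would read in the C-X-C chemokine receptor type 3 assay.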